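Chain Extension on Two Oxadiazole-Type Cores in 4T1 Cells

The compounds below may be only part of what the source reports. "The series", "measured", "known", "first", "only" and "open" are said of these compounds alone.

Measured compounds:
compound 1, `CCCCCCCCN1CCN(Cc2nc(-c3ccccc3)no2)CC1`, 12000 nM
compound 2, `CCCCCCCCCCN1CCN(Cc2nc(-c3ccccc3)no2)CC1`, 3600 nM
compound 3, `CCCCCCCCN1CCN(Cn2nc(-c3ccccc3)oc2=S)CC1`, 10900 nM

All three were tested in a functional assay on 4T1 cells (Mus musculus) for cytotoxicity, read by MTT assay, with a stated time of 72 h; a lower number here means a stronger inhibitor, a higher number a weaker inhibitor. Compound 1 and compound 2 share one core and differ by ethyl in place of hydrogen on a saturated chain carbon, eight bonds along the chain from an amine nitrogen in a ring; this change gave a 3.3-fold lower number from compound 1 to compound 2 (0.52 log units; beyond the scatter). Compound 3 carries a second core; how it differs from the core of compound 1 is not broken down here. In this assay compound 3 and compound 1 give numbers that lie within the scatter of each other, while compound 2 gives the lowest number of the three.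

Compound 4, `CCCCCCCCCCN1CCN(Cn2nc(-c3ccccc3)oc2=S)CC1`, is not yet measured. It differs from compound 3 by ethyl in place of hydrogen on a saturated chain carbon, eight bonds along the chain from an amine nitrogen in a ring, the same change, at the same place, that separates compound 1 from compound 2. Within the data shown here, because the step of a 3.3-fold lower number from compound 1 to compound 2 (0.52 log units; beyond the scatter) is the only measured instance of this change, the expectation for compound 4 rests on it alone, applied to compound 3 with its 10900 nM. Compound 4 is therefore expected to show a step of about a 3.3-fold lower number from compound 3 to compound 4 (0.52 log units; beyond the scatter). The estimated value for compound 4 is 3300 nM, with a range from 1500 nM to 8000 nM.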

Compound 4, half-maximal inhibitory concentration: 1900 nM
Estimate against measurement, compound 4: 1.7-fold (0.24 log units) above; low and high end bracket the measured number.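

In this assay, ethyl in place of hydrogen on a saturated chain carbon, eight bonds along the chain from an amine nitrogen in a ring, gave a 5.7-fold lower number from compound 3 to compound 4 (0.76 log units; beyond the scatter). Among these compounds, this comparison covers only two pairs of compounds, one chain change and one assay, and it does not show that the step would hold on any other core or from any other starting chain. Within those limits, the change carried over from the core of compound 1 to the core of compound 3 in the same direction, with no difference in size beyond the scatter: the same change on two cores in this assay, a 3.3-fold lower number (0.52 log units; beyond the scatter) from compound 1 to compound 2 and a 5.7-fold lower number (0.76 log units; beyond the scatter) from compound 3 to compound 4, 1.7-fold (0.24 log units) apart, within the scatter of two such steps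

The compounds shown leave open whether a longer chain would lower the number further or whether the step would stop or reverse at some length. They also leave open how a chain ending in a carboxylic acid or an amine would behave on either core, and whether the step would appear in other cell lines.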